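Swapping Trifluoromethyl for Chloro on the Acid Ring

The compounds below may be only part of what the source reports. "The series", "measured", "known", "first", "only" and "open" are said of these compounds alone.

Three measured compounds share one core, and their repeat results set the scene. Compound 1 `O=C(O)c1ccc(F)cc1-c1ccc2c(c1)OC[C@H](Cc1ccccc1)[C@H]2O` gives in a functional assay on blood with leukotriene B4 receptor (Homo sapiens) as the target (a lower number here means a stronger inhibitor, a higher number a weaker inhibitor), the values 600 nM; 3500 nM (2 entries), and compound 2 `O=C(O)c1ccc(Cl)cc1-c1ccc2c(c1)OC[C@H](Cc1ccc(-c3ccccc3)cc1)[C@H]2O` gives 3900 nM; 1700 nM (2 entries). The repeats of compound 1 the several entries of compound 1 in this assay, 600 nM; 3500 nM (2 entries) and of compound 2 the several entries of compound 2 in this assay, 3900 nM; 1700 nM (2 entries) show how far two runs of one compound can lie apart. Going by the values given here, compound 3 `O=C(O)c1ccc(C(F)(F)F)cc1-c1ccc2c(c1)OC[C@H](Cc1ccccc1)[C@H]2O` gives 660 nM, the only number it has; two further entries for it carry no single number. Among the numbers shown, compound 3 sits beside the lower entry of compound 1 and under both entries of compound 2.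

Compound 4 `O=C(O)c1ccc(Cl)cc1-c1ccc2c(c1)OC[C@H](Cc1ccccc1)[C@H]2O` differs from compound 3 in one place: chloro in place of trifluoromethyl on an aromatic carbon. Among the compounds with values here, no measured pair in this set differs in just that way, so the size of the step is open. The step from compound 3 to compound 4 is expected to stay within the ordinary scatter, a 1.2-fold higher number from compound 3 to compound 4 (0.08 log units; within the scatter). Compound 4 is therefore estimated at 800 nM, in the range 250 nM to 3000 nM.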

Compound 4, half-maximal inhibitory concentration: 1300 nM
For compound 4 the middle estimate is 1.6-fold (0.21 log units) below the measured one; measured number inside the range.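

Going by these compounds alone, on the aromatic carbon para to a carboxy group, chloro in place of trifluoromethyl gives a 2.0-fold higher number from compound 3 to compound 4 (0.29 log units; within the scatter) in this assay and provides the first direct reading of a single exchange in this set. A lone chlorine atom can therefore stand where four heavy atoms stood without the step leaving the scatter. Two runs of a single compound can lie further apart than this whole step: the several entries of compound 1 in this assay, 600 nM; 3500 nM (2 entries).

Within the data shown here, with only one exchange read at this carbon and only one number for compound 3, neither the direction nor the true size of the step is settled. As far as these compounds go, how a much different group, such as an amine or a nitrile, would fare on this same carbon remains open.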